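Thioether swap: naphthalenylmethyl in place of benzoylmethyl

The compounds below may be only part of what the source reports. "The series", "measured", "known", "first", "only" and "open" are said of these compounds alone.

Measured compounds:
- compound 1, `Cc1cc(Nc2cc(-c3ccccc3)[nH]n2)n2nc(SCC(=O)c3ccccc3)nc2n1`: 2580 nM
- compound 2, `Cc1cc(Nc2ccn(Cc3ccc(F)cc3)n2)n2nc(SCc3ccc(Br)cc3)nc2n1`: 3070 nM

Both compounds share a core that carries a thioether side chain. In a functional assay on MGC-803 cells (Homo sapiens) for inhibition, read by MTT assay, with a stated time of 72 h (a lower number here means a stronger inhibitor, a higher number a weaker inhibitor), compound 1 gives 2580 nM, and compound 2 gives 3070 nM. Compound 1 has the lowest of the two numbers, but its gap to compound 2 is within the scatter, so the two cannot be told apart on these numbers.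

Compound 3, `Cc1cc(Nc2cc(-c3ccccc3)[nH]n2)n2nc(SCc3cccc4ccccc34)nc2n1`, is not yet measured. It keeps the whole of compound 1 apart from one change on the thioether chain: naphthalen-1-yl in place of benzoyl on a saturated chain carbon bound to a sulfur. The group that leaves carries a carbonyl; the group that enters is a pair of fused aromatic rings with no hydrogen-bond acceptor. Among the measured compounds shown here, no pair of measured compounds that differ only at this place exists here, so the size and direction of this step cannot be read from any measured pair.

With compound 1 at 2580 nM, the step expected in this assay from compound 1 to compound 3, a 1.2-fold lower number from compound 1 to compound 3 (0.07 log units; within the scatter), is small and not beyond the scatter. The estimate for compound 3 in this assay is 2200 nM, with a range from 900 nM to 5500 nM.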

Compound 3, half-maximal inhibitory concentration: 3120 nM
Compound 3: the middle estimate sits 1.4-fold (0.15 log units) below what was measured, within the range that was stated.
By their numbers in this assay, from the lowest: compounds 1, 2 and 3 (each within the scatter of the next).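

Among the compounds shown here, this is the first pair of measured compounds that differ in one place, so the thioether chain can now be read directly: in this assay, naphthalen-1-yl in place of benzoyl on a saturated chain carbon bound to a sulfur gives a 1.2-fold higher number from compound 1 to compound 3 (0.08 log units; within the scatter) and thus no step beyond the scatter. The carbonyl of benzoyl and its single aromatic ring can therefore be exchanged for a pair of fused aromatic rings with no hydrogen-bond acceptor, and the two compounds still cannot be told apart on this read-out. No measurement shown here offers an explanation for this result.

As far as these compounds go, both groups at this place are built around aromatic carbon rings, so it remains open whether a group of another kind, such as an amine or a carboxylic acid, or a longer chain between the sulfur and the ring, would give a step beyond the scatter. Compound 2 differs from compound 1 in more than one place, so it cannot help to answer this.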